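The compounds below may be only part of what the source reports. "The series", "measured", "known", "first", "only" and "open" are said of these compounds alone.

Measured compounds in the series:
- compound 1, `O=S(=O)(Nc1ccc(F)c(C#Cc2cnc3[nH]ccc3c2)c1F)c1cccnc1`: > 10000 nM in a functional assay on HCT-116 cells (Homo sapiens) for antiproliferative activity, read by MTT assay, with a stated time of 68 h; a lower number here means a stronger inhibitor, a higher number a weaker inhibitor
- compound 2, `CCOc1n[nH]c2ncc(C#Cc3c(F)ccc(NS(=O)(=O)c4cccnc4)c3F)cc12`: 10000 nM in this assay

Both measured compounds share a core and differ at a single aromatic carbon of the fused five-membered ring. For compound 1 the value > 10000 nM in this assay is a limit of the assay and not a number. Going by the values given here, compound 2, with its ethoxy group, is the only compound of the two for which an actual number stands; the other value sits at the limit of > 10000 nM in this assay, at which 1 of the 2 values shown sits. Among the compounds with values here, no step between two measured compounds can be read from this, so the size of a change at this position is unknown.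

Compound 3, `O=S(=O)(Nc1ccc(F)c(C#Cc2cnc3[nH]nc(-c4ccccc4Cl)c3c2)c1F)c1cccnc1`, is not yet measured. It differs from compound 2 by 2-chlorophenyl in place of ethoxy on an aromatic carbon. Within the data shown here, no measured step supports a direction, so the expected step of a 2.0-fold lower number from compound 2 to compound 3 (0.30 log units; within the scatter) in this assay is taken as modest, toward stronger inhibition, but with wide uncertainty and possibly no more than the scatter. Compound 3 is expected at 5000 nM in this assay, within a range from 1000 nM to 20000 nM.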

Compound 3, half-maximal inhibitory concentration: > 10000 nM
Compound 3 ended at the assay's limit; the forecaster's own chance of this, stated with the estimate: 35%; middle value at least 2.0-fold (0.30 log units) from the limit.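

In this assay, placing 2-chlorophenyl instead of ethoxy on this aromatic carbon gives a number no lower from compound 2 to compound 3 (the limit leaves the size open). Compound 3 gives > 10000 nM, which is a limit of the assay and not a number, so the size of this step cannot be read. The position now carries an aromatic ring as well as ethoxy, and the ring brings no lower number than ethoxy, so most of the series remains at the limit: the limit of > 10000 nM in this assay, at which 2 of the 3 values shown sit.

Still open, going by these compounds, is whether a phenyl without the chlorine, an amine or a longer alkoxy chain on this carbon would give a number clearly lower than that of compound 2, 10000 nM. Also open, on these data alone, is how far compound 1 and compound 3 lie beyond the limit they share, and so whether either differs from the other in this assay.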